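Sulfoximine Exchange at the Distal Aryl Group

The source may report more compounds than this note shows. Statements on the series, on what has been measured and on what is new or still open speak of the compounds shown alone.

Measured compounds:
compound 1, `CC#C[C@H]1CN(S(=O)(=O)c2ccc(N)nc2)CCN1c1ccc([C@@](O)(CO)C(F)(F)F)cc1`, 89 nM
compound 2, `CC#C[C@H]1CN(S(=O)(=O)c2ccc(N)nc2)CCN1c1ccc(S(=O)(=NC)C(F)(F)F)cc1`, 2060 nM
compound 3, `C#CCC(O)(c1ccc(N2CCN(S(=O)(=O)c3ccc(N)nc3)C[C@@H]2C#CC)cc1)C(F)(F)F`, 130 nM

The three compounds share one core and differ only in the group carried on the aromatic carbon of the distal ring. In an assay on cells (Hepatocyte) for inhibition of glucokinase regulatory protein (Mus musculus), with stated times of 20 min and 40 min (on this read-out higher numbers stand for an effect only at larger amounts of compound and lower numbers for an effect already at smaller amounts), compound 2 gives the highest number of the three: a 23-fold higher number from compound 1 to compound 2 (1.36 log units; beyond the scatter) and a 16-fold lower number from compound 2 to compound 3 (1.20 log units; beyond the scatter) both separate it clearly from the two alcohol-bearing compounds, while compound 1 and compound 3 lie within the scatter of each other (a 1.5-fold higher number from compound 1 to compound 3 (0.16 log units; within the scatter)).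

Compound 4, `CC#C[C@H]1CN(S(=O)(=O)c2ccc(N)nc2)CCN1c1ccc(S(C)(=N)=O)cc1`, has not been measured. Relative to compound 2 the change is a group of 4 heavy atoms (1 carbon, 1 nitrogen, 1 oxygen, 1 sulfur; no ring) in place of a group of 8 heavy atoms (2 carbon, 1 nitrogen, 1 oxygen, 3 fluorine, 1 sulfur; no ring), on an aromatic carbon. Among the measured compounds shown here, no measured step exchanges one sulfoximine for another, so the two large steps away from compound 2 bear only indirectly: they show that the group of compound 2 is the least favourable among the three, and that both better-performing compounds carry a hydrogen-bond donor, as compound 4 does. A lower number is therefore expected, but of uncertain size; compound 4 is estimated at 500 nM (range 120 nM to 2000 nM), an expected step of a 4.1-fold lower number from compound 2 to compound 4 (0.61 log units; beyond the scatter).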

Compound 4, half-maximal effective concentration: 704 nM
Compound 4: the middle estimate sits 1.4-fold (0.15 log units) below what was measured, within the range that was stated.
By their numbers in this assay, from the lowest: compounds 1 and 3 (each within the scatter of the next); then compound 4; then compound 2.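

Among the compounds shown here, for the first time, two sulfoximines can be compared on this aromatic carbon: in this assay, a 2.9-fold lower number from compound 2 to compound 4 (0.47 log units; beyond the scatter) accompanies the exchange of a larger group without a hydrogen-bond donor for a smaller one with a hydrogen-bond donor. This sulfoximine still does not reach the two alcohol-bearing compounds, with a 7.9-fold higher number from compound 1 to compound 4 (0.90 log units; beyond the scatter) and a 5.4-fold higher number from compound 3 to compound 4 (0.73 log units; beyond the scatter), so carrying a hydrogen-bond donor does not by itself match them among these compounds. No measurement shown accounts for these differences.

The step replaces the trifluoromethyl on sulfur with methyl and, at the same time, the methyl on the sulfoximine nitrogen with hydrogen, so the contribution of each exchange remains unresolved. On these data alone, how a methyl sulfone or a carboxylic acid on the same aromatic carbon would compare also remains open.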